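The compounds below may be only part of what the source reports. "The series", "measured", "known", "first", "only" and "open" are said of these compounds alone.

Compound 1 `C=CC1=C(C(=O)NCCC)C(c2ccc(F)cc2)OC1`: in a functional assay on HeLa cells (Homo sapiens) for cytotoxicity, read by MTT assay, with a stated time of 24 h (a lower number here means a stronger inhibitor, a higher number a weaker inhibitor), compound 1 gives > 100000 nM, which is a limit of the assay.
Compound 2 `C=CC1=C(C(=O)NCc2ccc(C)cc2)C(c2ccc(F)cc2)OC1`: in this assay compound 2 gives > 100000 nM, likewise a limit.
Compound 3 `C=CC1=C(C(=O)NCCC)C(c2ccc(OC)c(OC)c2)OC1`: in this assay compound 3 gives > 100000 nM, again a limit.

Compound 4 `C=CC1=C(C(=O)NCc2ccc(C)cc2)C(c2ccc(OC)c(OC)c2)OC1` has not yet been measured. The change from compound 1 to compound 2 is 4-methylphenyl in place of ethyl on a saturated chain carbon bound to an amide-type nitrogen, and in this assay it gave a step that the two limits leave unreadable from compound 1 to compound 2. The size of that step cannot be read because of the limit of > 100000 nM in this assay, at which 3 of the 3 values shown sit. The same change is made from compound 3 to compound 4, (4-methylphenyl in place of ethyl on a saturated chain carbon bound to an amide-type nitrogen), at the same place; the difference between the two cores is not broken down here. For compound 4 the expected step in this assay is a step that the limit leaves unreadable from compound 3 to compound 4. That expectation rests on compound 3 sitting at a limit, > 100000 nM, and on (the limit of > 100000 nM in this assay, at which 3 of the 3 values shown sit). Compound 4 is therefore estimated at 150000 nM, expected to fall between 70000 nM and 500000 nM.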

Compound 4, half-maximal inhibitory concentration: > 100000 nM
Compound 4: only a limit was reported; the forecaster's own chance of this, stated with the estimate: 85%; the middle value lies beyond the limit too.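

No step from compound 3 to compound 4 can be read in this assay, as compound 4 also stands at a limit: the limit of > 100000 nM in this assay, at which 4 of the 4 values shown sit.

The compounds shown leave open whether propyl to 4-methylbenzyl changes cytotoxicity at all.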